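The compounds below may be only part of what the source reports. "The series", "measured", "known", "first", "only" and "open" are said of these compounds alone.

Two compounds have been measured so far in an ADME assay on L1210/0 cells (Mus musculus) for cytotoxicity, with a stated time of 48 h; a lower number here means a stronger inhibitor, a higher number a weaker inhibitor

Compound 1 `Cc1ccc(-c2ncnc3c2ncn3C[C@@H]2C[C@H](CO)c3ccccc32)cc1` gives 15400 nM
Compound 2 `N#CSc1cn([C@H]2C[C@H](O)[C@@H](CO)O2)c(=O)[nH]c1=O` gives 78900 nM

Of the two, compound 2 has the higher number and is therefore the weaker inhibitor, and its gap to compound 1 lies beyond the usual scatter. Among the measured compounds shown here, the two compounds do not differ in just one place, so no measured step is available as a guide.

Compound 3 `[N-]=[N+]=NCc1cn([C@H]2C[C@H](O)[C@@H](CO)O2)c(=O)[nH]c1=O` is still to be measured. It has azidomethyl in place of cyanosulfanyl on an aromatic carbon and otherwise matches compound 2. Nothing measured here shows what this exchange does, so any expectation is loose. With compound 2 at 78900 nM as the higher of the two numbers, a modest move towards a lower number is expected in this assay though a step within the scatter would be no surprise. The expected step is estimated as a 3.2-fold lower number from compound 2 to compound 3 (0.50 log units; beyond the scatter) and remains uncertain in size. The estimated value for compound 3 is 25000 nM with an expected range from 3000 nM to 150000 nM for this measurement.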

Compound 3, half-maximal inhibitory concentration: 124000 nM
Beside the measured number, compound 3's estimate is 5.0-fold (0.70 log units) below it, and the stated range covers the measured number.
By their numbers in this assay, from the lowest: compound 1; then compounds 2 and 3 (each within the scatter of the next).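

In this assay, among the compounds shown here, the exchange of cyanosulfanyl for azidomethyl, on the aromatic carbon two atoms from the ring nitrogen, gives a 1.6-fold higher number from compound 2 to compound 3 (0.20 log units; within the scatter) and is the only step between compounds that differ in one place. It shows that these two groups cannot be told apart in this read-out, although one brings a sulfur atom and a triple bond and the other brings three nitrogen atoms and two double bonds, with no ring or net charge in either. No measured information bears on why the two groups read alike, so this result stands without an explanation.

The compounds shown leave open whether any group at this position can move the number beyond the scatter, as a single pair with one exchange says little about the position as a whole, and compound 1 differs from both in more than one place and cannot help. An amine, a carboxylic acid or a longer chain on this aromatic carbon would test whether the result holds for groups of other kinds.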